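Methoxy in Place of Hydrogen on the Core of Compound 1

The compounds below may be only part of what the source reports. "The series", "measured", "known", "first", "only" and "open" are said of these compounds alone.

Measured compounds:
compound 1 `O=C1NC(=O)/C(=C/c2cn(Cc3ccccc3)c3ccccc23)N1`: 14200 nM
compound 2 `O=C1NC(=O)/C(=C/c2cn(Cc3ccccc3Br)c3ccccc23)N1`: 16900 nM

In a functional assay on NCI-H460 cells (Homo sapiens) for antiproliferative activity, read by trypan blue exclusion, with a stated time of 24 h (on this read-out higher numbers stand for weaker inhibition and lower numbers for stronger inhibition), compound 1 gives 14200 nM, and compound 2 gives 16900 nM. Among the compounds with values here, the one measured step, a 1.2-fold higher number from compound 1 to compound 2 (0.08 log units; within the scatter), lies within the scatter, so compound 1 stands as one of two numbers that cannot be told apart on this read-out. Compound 3 `COc1ccc2c(c1)c(/C=C1\NC(=O)NC1=O)cn2Cc1ccccc1` differs from compound 1 by methoxy in place of hydrogen on an aromatic carbon. Within the data shown here, the only measured step, a 1.2-fold higher number from compound 1 to compound 2 (0.08 log units; within the scatter), concerns a different place on the shared core and is itself within the scatter, so no measured step bears directly on this exchange of methoxy for hydrogen. Nothing in the two measured compounds points to a movement in either direction. For compound 3 the expected step is a 1.0-fold lower number from compound 1 to compound 3 (0.01 log units; within the scatter), that is, none beyond the scatter. Compound 3 is therefore estimated at 14000 nM, with a range from 6000 nM to 32000 nM.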

Compound 3, half-maximal inhibitory concentration: 28400 nM
Compound 3: middle estimate off by 2.0-fold (0.31 log units), on the low side; measured number inside the range.
By their numbers in this assay, from the lowest: compounds 1, 2 and 3 (each within the scatter of the next).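

In this assay, methoxy on an aromatic carbon of the six-membered aromatic ring of carbon only, meta to a fused ring and para to a fused ring, gives a 2.0-fold higher number from compound 1 to compound 3 (0.30 log units; within the scatter). Within the data shown here, this is the first measured step at this place on the shared core, and it shows that methoxy can stand here with a number that cannot be told apart from that of the parent on this read-out. No supporting measurement is available that would say anything further about this exchange.

Going by these compounds, it remains open whether a different group at this same carbon, such as an amine, a carboxylic acid or a longer chain like ethoxy, would give a step beyond the scatter. On these data alone, it is equally open how methoxy would read on the other carbons of this ring.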